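From 4-aminophenyl to piperazin-1-yl on one carbon

The compounds below may be only part of what the source reports. "The series", "measured", "known", "first", "only" and "open" are said of these compounds alone.

In a functional assay on HepG2 cells (Homo sapiens) for inhibition, read by MTT assay, with a stated time of 72 h (a higher number here means a weaker inhibitor, a lower number a stronger inhibitor), compound 3 `CC(C)(C)n1cc2c(n1)C(=O)CC1(CCN(C(=O)c3cc(-c4ccc(N)cc4)nc4ccccc34)CC1)O2` gives 630 nM and compound 2 `CC(C)(C)n1cc2c(n1)C(=O)CC1(CCN(C(=O)c3cc(-c4ccc(Br)cc4)nc4ccccc34)CC1)O2` gives 820 nM with a 1.3-fold lower number from compound 2 to compound 3 (0.11 log units; within the scatter) separating them, so the two stand level. Compound 1 `Cc1ccccc1-c1cc(C(=O)N2CCC3(CC2)CC(=O)c2nn(C(C)(C)C)cc2O3)c2ccccc2n1` gives only a limit of the assay, > 10000 nM and no number. Exchanging the group on this carbon gave an at least 12-fold lower number from compound 1 to compound 2 (1.08 log units; beyond the scatter) and also an at least 15-fold lower number from compound 1 to compound 3 (1.20 log units; beyond the scatter) so both steps were large and the place clearly matters. Within the data shown here, compound 4 `CC(C)(C)n1cc2c(n1)C(=O)CC1(CCN(C(=O)c3cc(N4CCNCC4)nc4ccccc34)CC1)O2` carries piperazin-1-yl in place of 4-aminophenyl on an aromatic carbon and no measured step puts a non-aromatic ring there. A moderate move to weaker inhibition is therefore expected, an estimated 2.4-fold higher number from compound 3 to compound 4 (0.38 log units; beyond the scatter) with wide uncertainty. Compound 4 is estimated at 1500 nM with 300 nM to 8000 nM as the expected range.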

Compound 4, half-maximal inhibitory concentration: 8570 nM
Beside the measured number, compound 4's estimate is 5.7-fold (0.76 log units) below it; measured number outside the range, above it.
By their numbers in this assay, from the lowest: compounds 3 and 2 (each within the scatter of the next); then compound 4. At a limit, above all of these: compound 1.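

Until now this carbon carried only substituted phenyl rings, and the non-aromatic piperazin-1-yl shows that the place does not accept just any six-membered ring: the change gives a 14-fold higher number from compound 3 to compound 4 (1.13 log units; beyond the scatter) and a 10-fold higher number from compound 2 to compound 4 (1.02 log units; beyond the scatter), and in place of 2-methylphenyl it gives an at least 1.1-fold lower number from compound 1 to compound 4 (0.06 log units; that floor lies within the scatter). The level of compound 2 and compound 3 therefore does not carry over to this ring. Compound 1 gives only a limit of the assay, so its step to compound 4 is only a floor and sets no order between the two: the limit of > 10000 nM in this assay, at which 1 of the 4 values shown sits.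

Still open, going by these compounds, is whether the loss follows the aromatic ring or the ring nitrogens, a question that a cyclohexyl or piperidin-1-yl group on this carbon would address.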